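Compound 1 to Compound 3: Tolerance in Cells

A few compounds are considered here, and "the series" means these few. Any claim that something is new, unique, unknown or untested is made for them only; others in the source may bear on it.

Measured in a functional assay on C8166 cells (Homo sapiens) for cytotoxicity, read by MTT assay, with a stated time of 72 h; a higher number here means that more compound is tolerated, a lower number that less compound is tolerated:
- compound 1 `Cc1ccc(S(=O)(=O)N2CC3(C[C@H]2C(=O)NN)SCCS3)cc1`: > 519000 nM (a limit)
- compound 2 `COc1ccc(/C=C/C(=O)N2C[C@@H](NC(=O)c3cccnc3)C[C@H]2C(=O)NO)cc1OC`: > 454000 nM (a limit)

Neither compound has a measured number in this assay, so their order cannot be told. Compound 1 stands at > 519000 nM, which is a limit. Compound 2 stands at > 454000 nM, which is also a limit.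

Compound 3 `Cc1ccc(S(=O)(=O)N2CC3(C[C@H]2C(=O)N/N=C/c2ccccc2Cl)SCCS3)cc1` keeps the core of compound 1 and differs at one place, on an amide-type nitrogen: a group of 9 heavy atoms (7 carbon, 1 nitrogen, 1 chlorine; one six-membered aromatic ring of carbon only) in place of one nitrogen atom, on an amide-type nitrogen. The amino group leaves, and a group with one six-membered aromatic ring of carbon only enters. For the measured compounds named here, no measured pair here shows what such a change does in this assay, so the expectation is loose. Going by the values given here, its only starting point is compound 1 at > 519000 nM, itself a limit.

The expected move is toward less compound tolerated, and the estimated size is an at least 3.4-fold lower number from compound 1 to compound 3 (0.53 log units; beyond the scatter). The assay may again report only a limit. Compound 3 is estimated at 150000 nM, with an expected range from 30000 nM to 420000 nM.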

Compound 3, half-maximal cytotoxic concentration: > 404000 nM
Compound 3: only a limit was reported; the forecaster's own chance of this, stated with the estimate: 50%; at least 2.6-fold (0.43 log units) between middle value and limit.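

In this assay compound 3 gives > 404000 nM, which is a limit. Compound 1 gives > 519000 nM, also a limit, so no step can be read between compound 1 and compound 3. The compounds shown leave open whether replacing the amino group with the group bearing the six-membered aromatic ring changes how much compound is tolerated at all.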